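The compounds below may be only part of what the source reports. "The series", "measured", "known", "first", "only" and "open" are said of these compounds alone.

Three measured compounds set the frame. In an assay on liver for inhibition of sterol O-acyltransferase 1 (Rattus norvegicus), using microsomes (a higher number here means a weaker inhibitor, a lower number a stronger inhibitor), compound 1 `CC(C)c1cccc(C(C)C)c1OC(=O)NS(=O)(=O)N(c1ccccc1)c1ccccc1` gives 58000 nM, compound 2 `CC(C)c1cccc(C(C)C)c1OS(=O)(=O)NC(=O)O[C@@H]1C[C@H](C)CCC1C(C)C` gives 21000 nM, and compound 3 `CC(C)c1cccc(C(C)C)c1OS(=O)(=O)NC(=O)OC1[C@H](C(C)C)CCC[C@H]1C(C)C` gives 5700 nM. Compound 2 thus stands second highest of the three numbers: compound 1 sits above it and compound 3 below it, both by more than the usual scatter of this assay. Compound 4 `Cc1cccc(C)c1OC(=O)NS(=O)(=O)Oc1c(C(C)C)cccc1C(C)C` has not been measured yet. It differs from compound 2 in one place: 2,6-dimethylphenyl in place of 2-isopropyl-5-methylcyclohexyl on an oxygen next to a carbonyl group. For the measured compounds named here, no measured pair shows this exchange, so the direction is uncertain; the account expects compound 4 to be a somewhat weaker inhibitor than compound 2, a step of a 1.9-fold higher number from compound 2 to compound 4 (0.28 log units; within the scatter). For compound 4 the estimate in this assay is 40000 nM, with a range from 10000 nM to 150000 nM.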

Compound 4, half-maximal inhibitory concentration: > 50000 nM
Compound 4 was reported as a limit; the forecaster's own chance of this, stated with the estimate: 15%; middle value at least 1.2-fold (0.09 log units) away from the limit.
By their numbers in this assay, from the lowest: compound 3; then compound 2; then compound 1.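

Compound 4 is reported only as a limit, > 50000 nM in this assay. Even so, this first one-place exchange on the oxygen next to a carbonyl group can be read in one direction: 2,6-dimethylphenyl in place of 2-isopropyl-5-methylcyclohexyl gives an at least 2.3-fold higher number from compound 2 to compound 4 (0.37 log units; beyond the scatter), so this aromatic group does not match the inhibition of compound 2. The full size of the step remains unknown: the limit of > 50000 nM in this assay, at which 1 of the 4 values shown sits.

From the compounds shown here alone, whether the loss follows from the aromatic ring or from its two methyl groups remains open. So does how a plain cyclohexyl or an unsubstituted phenyl would read on this oxygen.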